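This account rests on a few compounds, and the source may have more. Where it says the series, first, only, none or still open, it means among the compounds named here.

Measured so far in an in vitro functional assay on cells for agonist activity at Bombesin receptor subtype-3 (Mus musculus), read by luminescence and calcium flux; on this read-out lower numbers stand for an effect already at smaller amounts and higher numbers for an effect only at larger amounts of compound:
- compound 1 `O=C(O)c1ccccc1-c1ccc(CCc2ncc(CCC3CCCCC3)[nH]2)cc1` gives 33 nM
- compound 2 `O=C(O)c1ccccc1-c1ccc(CCc2ncc(CC3CCCCCC3)[nH]2)cc1` gives 5.7 nM
- compound 3 `COc1ccccc1Cc1cnc(CCc2ccc(-c3ccccc3C(=O)O)cc2)[nH]1` gives 163 nM

Compound 2 has the lowest number of the three in this assay; its nearest neighbour is compound 1, by a 5.8-fold lower number from compound 1 to compound 2 (0.76 log units; beyond the scatter), and the furthest is compound 3, by a 29-fold higher number from compound 2 to compound 3 (1.46 log units; beyond the scatter). Both of these steps lie beyond the scatter.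

The next compound, compound 4 `O=C(O)c1ccccc1-c1ccc(CCc2ncc(Cc3cccc(F)c3F)[nH]2)cc1`, differs from compound 2 by 2,3-difluorophenyl in place of cycloheptyl on a saturated chain carbon bound to an aromatic carbon. An aromatic ring thus takes the place of the seven-membered non-aromatic ring on the saturated chain carbon bound to an aromatic carbon.

Going by the values given here, two measured steps bear on this. The closest is a 29-fold higher number from compound 2 to compound 3 (1.46 log units; beyond the scatter), where an aromatic ring likewise replaces the cycloheptyl; it is large. The related 4.9-fold higher number from compound 1 to compound 3 (0.69 log units; beyond the scatter), aromatic ring replacing cyclohexylmethyl, is modest. Among the compounds with values here, there is no measured pair that compares a 2,3-difluorophenyl with a 2-methoxyphenyl, so the size of the step for compound 4 is uncertain, but the direction in this assay is expected to be toward a higher number, with a step around an 11-fold higher number from compound 2 to compound 4 (1.02 log units; beyond the scatter).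

Compound 4 is therefore estimated at 60 nM, in the range 15 nM to 250 nM.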

Compound 4, half-maximal effective concentration: 8 nM
Beside the measured number, compound 4's estimate is 7.5-fold (0.88 log units) above it; the measured number lies below the stated range.
By their numbers in this assay, from the lowest: compounds 2 and 4 (each within the scatter of the next); then compound 1; then compound 3.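

In this assay, an aromatic ring on the saturated chain carbon bound to an aromatic carbon is not costly in itself: a 1.4-fold higher number from compound 2 to compound 4 (0.15 log units; within the scatter) leaves 2,3-difluorophenyl and cycloheptyl indistinguishable at this position. What the ring carries matters instead, as 2,3-difluorophenyl in place of 2-methoxyphenyl gives a 20-fold lower number from compound 3 to compound 4 (1.31 log units; beyond the scatter), so among the two aromatic groups shown, only compound 3 carries the large shift to a higher number. The same group also compares favourably with the cyclohexylmethyl, with a 4.1-fold lower number from compound 1 to compound 4 (0.62 log units; beyond the scatter), so this position tolerates both a non-aromatic and an aromatic ring at the low end of the series.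

Nothing available accounts for the difference between the 2-methoxyphenyl and the 2,3-difluorophenyl. Open questions are whether the gain follows from the two fluorines together or from one alone, whether a chlorine, a trifluoromethyl or a methoxy group elsewhere on the ring keeps the low number, and whether an amine on the ring or a longer chain to the ring is tolerated.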